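Opening the ring of compound 3

This account rests on a few compounds, and the source may have more. Where it says the series, first, only, none or still open, it means among the compounds named here.

In an ADME assay on the whole organism (strain CD-1) for metabolic stability, with Mus musculus as the target, at a dose of 3 mg/kg by the intravenous route (a higher number here means that the compound lasts longer, a lower number that the compound disappears faster), compound 1 `CN(Cc1ccccc1OCCCCCC(=O)O)C(=O)c1ccc(-c2ccco2)cc1` shows 1.7 h as its half-life, compound 2 `CN(Cc1ccccc1OCCCCC(C)(C)C(=O)O)C(=O)c1ccc(-c2ccco2)cc1` shows 4.6 h and compound 3 `CN(Cc1ccccc1OCCC[C@@H]1C[C@@H]1C(=O)O)C(=O)c1ccc(-c2ccco2)cc1` shows 2.7 h on the same shared core. Compound 3 cannot be told apart from either of the others, as both steps that reach it stay within the scatter (a 1.6-fold higher number from compound 1 to compound 3 (0.20 log units; within the scatter)) and (a 1.7-fold lower number from compound 2 to compound 3 (0.23 log units; within the scatter)). Within the data shown here, only one step clears the scatter (a 2.7-fold higher number from compound 1 to compound 2 (0.43 log units; beyond the scatter)), and it brings in 1-carboxy-1-methylethyl, with neither a ring nor a new double bond.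

Compound 4 `C/C(=C\C(=O)O)CCCOc1ccccc1CN(C)C(=O)c1ccc(-c2ccco2)cc1` has the same atoms as compound 3 joined differently, with 2-carboxy-1-methylethenyl in place of 2-carboxycyclopropyl on a saturated chain carbon, three bonds along the chain from an oxygen on an aromatic ring. Among the measured compounds shown here, no measured step makes this exact exchange. Because a 1.6-fold higher number from compound 1 to compound 3 (0.20 log units; within the scatter) is the closest measured exchange between an open chain and the ring and stays within the scatter, no step beyond the scatter is expected in this assay for this change. The estimated change is small (a 1.1-fold lower number from compound 3 to compound 4 (0.05 log units; within the scatter)). Compound 4 is expected to show about 2.4 h as its half-life, with an estimated range from 1.2 h to 4.6 h for its measurement.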

Compound 4, half-life: 1.6 h
Compound 4: middle estimate off by 1.5-fold (0.18 log units), on the high side, within the range that was stated.
By their numbers in this assay, from the lowest: compounds 4, 1, 3 and 2 (each within the scatter of the next, the first and the last beyond it).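

In this assay, the open 2-carboxy-1-methylethenyl group cannot be told apart from the 2-carboxycyclopropyl group at this position (a 1.7-fold lower number from compound 3 to compound 4 (0.23 log units; within the scatter)), nor from the saturated 2-carboxyethyl group (a 1.1-fold lower number from compound 1 to compound 4 (0.03 log units; within the scatter)), so neither the three-membered ring nor the added double bond gives a change that clears the scatter. The 2-carboxy-2-methylpropyl group of compound 2 now stands apart from two open-chain compounds, as the new comparison (a 2.9-fold lower number from compound 2 to compound 4 (0.46 log units; beyond the scatter)) joins the earlier gap to compound 1, though compound 3 goes against a clean split, since it lies within the scatter of compound 2. No measurement at hand explains why these half-lives fall as they do.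

The compounds shown leave open whether the gap seen with compound 2 would persist with a 1-carboxycyclopropyl or 1-carboxycyclobutyl group at the same place. They also leave open how a tetrazole in place of the carboxylic acid, or a longer chain, would read in this assay.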